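The compounds below may be only part of what the source reports. "The series", "measured", "known", "first", "only" and "open" are said of these compounds alone.

Compound 1 `CC(=O)O[C@@H]1OC(=O)[C@](O)(C(C)=O)[C@@H]1C` gives > 50000 nM in a functional assay on DA-3 cells for cytotoxicity against DA-3 cell line (Mus musculus), read by MTT assay (on this read-out higher numbers stand for weaker inhibition and lower numbers for stronger inhibition), a limit of the assay.
Compound 2 `CC(=O)O[C@@H]1OC(=O)[C@](OC(C)=O)(C(C)=O)[C@@H]1C` gives > 50000 nM in this assay, again a limit.
Compound 3 `CC(=O)O[C@@H]1OC(=O)[C@@](O)(C(C)=O)[C@@H]1C` gives > 50000 nM in this assay, also a limit.

From compound 1 to compound 2 the change is acetyl in place of hydrogen on an oxygen on a saturated carbon, and the step is a step that the two limits leave unreadable from compound 1 to compound 2. The cores of compound 1 and compound 3 differ in this way: the two compounds have the same atoms and bonds and differ only in configuration as drawn: 1 of 3 stereo elements differ; a stereocentre at a saturated ring carbon is drawn R in compound 1 and S in compound 3. Compound 4 `CC(=O)O[C@@H]1OC(=O)[C@@](OC(C)=O)(C(C)=O)[C@@H]1C` is not yet measured; it arises from compound 3 by acetyl in place of hydrogen on an oxygen on a saturated carbon, the same change as that from compound 1 to compound 2, at a place described in the same words. The step from compound 3 to compound 4 is expected to be a step that the limit leaves unreadable from compound 3 to compound 4, which rests on a step that the two limits leave unreadable from compound 1 to compound 2 together with the limit of > 50000 nM in this assay, at which 3 of the 3 values shown sit, so that a number may not emerge at all. Compound 4 is therefore estimated at 100000 nM in this assay, between 30000 nM and 300000 nM.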

Compound 4, half-maximal inhibitory concentration: > 50000 nM
Compound 4 gave a limit, no number; the forecaster's own chance of this, stated with the estimate: 85%; the middle value does not contradict the limit.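

Compound 4 gives only a limit in this assay, as do compound 2 and compound 3, so neither of its steps can be read. On these data alone, whether hydroxy to acetoxy or the drawn configuration affects cytotoxicity at all remains open.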